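This account rests on a few compounds, and the source may have more. Where it says the series, first, only, none or still open, it means among the compounds named here.

Of the compounds shown here, three sharing one core have been measured. Compound 3 `CCOC(=O)c1sc(-c2cccc(NC(=O)c3ccc(Cl)cc3)c2)nc1Nc1ccc(N2CCN(C)CC2)cc1` gives 24.3% in a functional assay on Raji cells (Homo sapiens) for antiproliferative activity, read by CCK-8 assay, with a stated time of 72 h, tested at 40 uM (a higher number here means more inhibition at the concentration tested (going by the name of the read-out), a lower number less inhibition), the second highest of the three numbers. Compound 2 `CCOC(=O)c1sc(-c2cccc(NC(=O)c3cccc(F)c3)c2)nc1Nc1ccc(N2CCN(C)CC2)cc1` gives 82.8% and compound 1 `CCOC(=O)c1sc(-c2cccc(NC(=O)c3ccc(C(C)(C)C)cc3)c2)nc1Nc1ccc(N2CCN(C)CC2)cc1` gives 4.22%. Compound 4 `CCOC(=O)c1sc(-c2cccc(NC(=O)c3ccco3)c2)nc1Nc1ccc(N2CCN(C)CC2)cc1` differs from compound 3 at the group on the carbonyl carbon: furan-2-yl in place of 4-chlorophenyl on a carbonyl carbon. Earlier changes at this same place moved the read-out strongly: a number 78.6 percentage points higher from compound 1 to compound 2 (beyond the scatter), a number 58.5 percentage points lower from compound 2 to compound 3 (beyond the scatter), and a number 20.1 percentage points higher from compound 1 to compound 3 (beyond the scatter). A smaller group entering there coincided with more inhibition in those steps, so a rise beyond the scatter is expected, though its size is uncertain. Compound 4 is estimated at 55%, within 20% to 88%, an expected step of a number 30.7 percentage points higher from compound 3 to compound 4 (beyond the scatter).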

Compound 4, a percentage reported as inhibition, at one concentration (the size of the read-out at that concentration, not a potency): 87.6%
Estimate against measurement, compound 4: 32.6 percentage points below; the range from low to high includes it.
By their numbers in this assay, from the lowest: compound 1; then compound 3; then compounds 2 and 4 (each within the scatter of the next).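

Putting furan-2-yl on this carbonyl carbon gives a number 63.3 percentage points higher from compound 3 to compound 4 (beyond the scatter) in this assay and a number 83.4 percentage points higher from compound 1 to compound 4 (beyond the scatter) when it replaces the 4-(tert-butyl)phenyl group. Against the 3-fluorophenyl group it gives a number 4.8 percentage points higher from compound 2 to compound 4 (within the scatter) and so cannot be told apart from it. High inhibition at this position is therefore not tied to one kind of ring: a five-membered ring with an oxygen and a six-membered carbon ring bearing fluorine both reach it.

Going by these compounds, whether an amine or a longer alkyl chain on this carbonyl carbon would keep that inhibition stays open. Nothing here gives a measured reason for these differences.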